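The source may report more compounds than this note shows. Statements on the series, on what has been measured and on what is new or still open speak of the compounds shown alone.

Working notes on the series. Within the data shown here, in a functional assay on cells (T-cell, Mus musculus, strain BALB/c) for inhibition, read by MTT assay, with a stated time of 72 h (a higher number here means a weaker inhibitor, a lower number a stronger inhibitor), compound 1 `COC(=O)c1cc(Cl)ccc1OC(=O)COc1cc(O)c2c(=O)cc(-c3ccccc3)oc2c1` gives 3740 nM, the second highest of the three numbers measured so far. The nearest neighbour on that scale is compound 2 `COC(=O)c1ccc(Cl)cc1OC(=O)COc1cc(O)c2c(=O)cc(-c3ccccc3)oc2c1`, which gives 12400 nM; the step is a 3.3-fold higher number from compound 1 to compound 2 (0.52 log units; beyond the scatter). The furthest is compound 3 `COC(=O)c1cc(Br)ccc1OC(=O)COc1cc(O)c2c(=O)cc(-c3ccccc3)oc2c1`, which gives 780 nM; that step is a 4.8-fold lower number from compound 1 to compound 3 (0.68 log units; beyond the scatter). Between the two other measured compounds the step is a 16-fold lower number from compound 2 to compound 3 (1.20 log units; beyond the scatter).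

Compound 4 `COC(=O)c1ccc(Br)cc1OC(=O)COc1cc(O)c2c(=O)cc(-c3ccccc3)oc2c1` is not yet measured. Against compound 1 the change is a group of 11 heavy atoms (8 carbon, 2 oxygen, 1 bromine; one six-membered aromatic ring of carbon only) in place of a group of 11 heavy atoms (8 carbon, 2 oxygen, 1 chlorine; one six-membered aromatic ring of carbon only), on an oxygen next to a carbonyl group. Compound 4 thus carries the bromine of compound 3 in the arrangement found in compound 2, so two measured steps bear on it: the move of the halogen, which gave a 3.3-fold higher number from compound 1 to compound 2 (0.52 log units; beyond the scatter), and the swap of chlorine for bromine, which gave a 4.8-fold lower number from compound 1 to compound 3 (0.68 log units; beyond the scatter). These pull in opposite directions and are of comparable size, so the step in this assay is expected to be small and may not exceed the scatter, with a slight lean toward a lower number. The step from compound 1 to compound 4 is estimated as a 1.3-fold lower number from compound 1 to compound 4 (0.13 log units; within the scatter). Compound 4 is therefore expected to give about 2800 nM, within a range from 900 nM to 9000 nM.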

Compound 4, half-maximal inhibitory concentration: 17600 nM
For compound 4 the middle estimate is 6.3-fold (0.80 log units) below the measured one, outside the stated range (above it).
By their numbers in this assay, from the lowest: compound 3; then compound 1; then compounds 2 and 4 (each within the scatter of the next).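

In this assay, the effect of bromo in place of chloro on an aromatic carbon depends on how the halogen is arranged in the group on an oxygen next to a carbonyl group: (the same change on two cores in this assay, a 4.8-fold lower number (0.68 log units; beyond the scatter) from compound 1 to compound 3 and a 1.4-fold higher number (0.15 log units; within the scatter) from compound 2 to compound 4, 6.8-fold (0.83 log units) apart, beyond the scatter of two such steps). In the arrangement of compound 2, bromo and chloro cannot be told apart (a 1.4-fold higher number from compound 2 to compound 4 (0.15 log units; within the scatter)), so the advantage of bromo seen in the arrangement of compound 1 does not carry over. The arrangement of compound 4 is also clearly unfavourable with bromo, as shown by the two steps to it (a 4.7-fold higher number from compound 1 to compound 4 (0.67 log units; beyond the scatter); a 23-fold higher number from compound 3 to compound 4 (1.35 log units; beyond the scatter)), and this leaves compound 3 as the strongest inhibitor of the four.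

The compounds shown cover only chloro and bromo in two arrangements, so it remains open whether fluoro, methyl or an amine on the same aromatic carbon would show the same dependence on arrangement. From the compounds shown here alone, the part played by the methoxycarbonyl group also remains open, and a carboxylic acid or an amide in its place would bear on this.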